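Swapping a cyanobenzyl for cyanomethyl on a sulfamide core

This account rests on a few compounds, and the source may have more. Where it says the series, first, only, none or still open, it means among the compounds named here.

Compound 1 `N#Cc1cccc(CN2C(=O)N(Cc3ccccc3)S(=O)(=O)n3cccc32)c1` was tested in an ADME assay on MT4 cells (Homo sapiens) for cytotoxicity, read by MTT assay, with a stated time of 5 days; a lower number here means that less compound is tolerated, a higher number that more compound is tolerated. In this assay compound 1 reaches only the limit of > 318000 nM, so no exact number is known for it (the limit of > 318000 nM in this assay, at which 1 of the 2 values shown sits). Compound 2 `O=C1N(Cc2cccc(Cl)c2)c2cccn2S(=O)(=O)N1Cc1cccc(F)c1` gives 208000 nM in this assay. Compound 3 `N#CCN1C(=O)N(Cc2ccccc2)S(=O)(=O)n2cccc21` is the next candidate; it differs from compound 1 by cyano in place of 3-cyanophenyl on a saturated chain carbon bound to an amide-type nitrogen in a ring. Among the measured compounds shown here, with no measured step of this kind available, the change from compound 1 to compound 3 is expected to bring no step beyond the scatter a step that the limit leaves unreadable from compound 1 to compound 3. Compound 3 is therefore estimated at 350000 nM, with a range from 150000 nM to 800000 nM.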

Compound 3, half-maximal cytotoxic concentration: 180000 nM
The estimate for compound 3 lay 1.9-fold (0.29 log units) above the measured number; measured number inside the range.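

Compound 3 shows that this position can lose the six-membered aromatic ring of 3-cyanophenyl, keeping only the cyano, and still give a high number: in this assay compound 3 gives 180000 nM. The change brings an at least 1.7-fold lower number from compound 1 to compound 3 (0.24 log units; that floor lies within the scatter). The value of compound 1 is a limit and not a number, so the full size of this step cannot be read: the limit of > 318000 nM in this assay, at which 1 of the 3 values shown sits.

Still open, from the compounds shown here alone, is how an amine, a carboxylic acid or a longer chain would read at this place. The compounds also leave open what a chain without the nitrile would give.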